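The source may report more compounds than this note shows. Statements on the series, on what has been measured and on what is new or still open speak of the compounds shown alone.

Among the measured compounds shown here, in a physicochemical assay for solubility, in phosphate buffer, with a stated time of 18 h, at pH 7.4 (on this read-out lower numbers stand for lower solubility and higher numbers for higher solubility), compound 1 (`COc1cc2ncnc(-n3nc(-c4ccccn4)nc3N)c2cc1[N+](=O)[O-]`) gives 2000 nM and compound 2 (`COc1cc2ncnc(-n3nc(-c4ccccn4)nc3N)c2cc1OCCCN(C)C`) gives 53000 nM in the same read-out, the highest of the two numbers so far. For the measured compounds named here, the only measured step, a 27-fold higher number from compound 1 to compound 2 (1.42 log units; beyond the scatter) on putting 3-(dimethylamino)propoxy in place of nitro on an aromatic carbon, is large. Compound 3 (`COc1cc2ncnc(-n3nc(-c4ccccn4)nc3N)c2cc1OCCCN1CC(C)OC(C)C1`) keeps the rest of compound 2 and differs in one place: 2,6-dimethylmorpholin-4-yl in place of dimethylamino on a saturated chain carbon, three bonds along the chain from an oxygen on an aromatic ring on a saturated chain carbon, three bonds along the chain from an oxygen on an aromatic ring. Going by the values given here, the measured step bears only indirectly, as no measured step replaces dimethylamino. A moderate downward move in this assay is therefore expected, well short of the measured step in size, with a 2.7-fold lower number from compound 2 to compound 3 (0.42 log units; beyond the scatter) as the estimated change. For compound 3 the estimated value is 20000 nM within an expected range of 6000 nM to 60000 nM in this read-out.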

Compound 3, solubility: 8000 nM
Estimate against measurement, compound 3: 2.5-fold (0.40 log units) above; measured number inside the range.
By their numbers in this assay, from the lowest: compound 1; then compound 3; then compound 2.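

In this assay the end of the chain matters as well as the chain itself: 2,6-dimethylmorpholin-4-yl in place of dimethylamino, on a saturated chain carbon, three bonds along the chain from an oxygen on an aromatic ring, gives a 6.6-fold lower number from compound 2 to compound 3 (0.82 log units; beyond the scatter) as a modest step beyond the scatter. Against nitro, the chain with this ring at its end still gives a 4.0-fold higher number from compound 1 to compound 3 (0.60 log units; beyond the scatter) as a modest step, so only part of the rise seen with 3-(dimethylamino)propoxy is given up among these compounds. No measurement shown here offers an explanation for the fall on this change.

The compounds shown leave open whether the fall follows the ring, its two methyl groups or its oxygen, which a plain morpholin-4-yl or a piperidin-1-yl end would separate. Also open, on these data alone, is how a longer chain at this place would read out.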